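Removing the Cyclopropyl from an Amide Nitrogen

The source may hold more compounds than are shown below. What is called first, only, known or untested is meant among the compounds shown, and "the series" means these compounds.

Measured so far in a functional assay on the whole organism for inhibition, with Rattus norvegicus as the target, at a dose of 20 mg/kg by the oral route; on this read-out lower numbers stand for less inhibition and higher numbers for more inhibition at the one dose given (going by the name of the read-out):
Compound 1, `CNC(=O)/C=C1\CCc2c(C)cc(F)cc21`, gives 77%.
Compound 2, `CNC(=O)/C=C1\CCc2c(Cl)cc(Cl)cc21`, gives 12%.
Compound 3, `O=C(/C=C1\CCc2cc(Cl)c(F)cc21)NC1CC1`, gives 27%.

Compound 3 stands second of the three in this assay. Its number lies above that of compound 2 and below that of compound 1, and both gaps are beyond the usual scatter of repeated measurements. Compound 3 differs from each of the other two both in the ring halogens and in the group on the amide nitrogen, so the numbers alone cannot say which part of the structure accounts for either gap.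

Compound 4, `NC(=O)/C=C1\CCc2cc(Cl)c(F)cc21`, has not yet been measured. It differs from compound 3 in one place: hydrogen in place of cyclopropyl on an amide-type nitrogen. Going by the values given here, no pair of measured compounds shows the effect of this kind of change on its own, so nothing measured here points in a direction. A step of modest size, possibly none beyond the scatter, is expected, and the estimated step is a number 3 percentage points higher from compound 3 to compound 4 (within the scatter). Compound 4 is therefore estimated at 30%, with an expected range from 5% to 65%.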

Compound 4, a percentage reported as inhibition, in the whole organism at one dose (the size of the read-out at that dose, not a potency): 19%
Estimate against measurement, compound 4: 11 percentage points above, within the range that was stated.
By their numbers in this assay, from the lowest: compounds 2, 4 and 3 (each within the scatter of the next, the first and the last beyond it); then compound 1.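

Going by these compounds alone, this is the first pair in which only the group on the amide nitrogen changes: in this assay, replacing cyclopropyl with hydrogen gives a number 8 percentage points lower from compound 3 to compound 4 (within the scatter). With the ring halogens of these two compounds, the cyclopropyl can therefore be removed without a change that stands out from the scatter of the read-out. Nothing available bears on why the two compounds read as they do.

The compounds shown leave open whether the same change would give a similar step with the ring substituents of compound 1, where the number is much higher, or with those of compound 2. What a longer chain such as butyl, or a chain ending in an amine, would do on this same nitrogen also remains an open question.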